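Extending the Ester Chain: From Propyl to Pentyl

A few compounds are considered here, and "the series" means these few. Any claim that something is new, unique, unknown or untested is made for them only; others in the source may bear on it.

Compound 1 `COC(=O)C(C)ON1C(=O)c2ccccc2C1=O`: 64% in a functional assay on the whole organism for inhibition, with Lepidium sativum as the target, tested at 1 ppm; on this read-out lower numbers stand for less inhibition of growth and higher numbers for more inhibition of growth at the one concentration tested
Compound 2 `CC(C)OC(=O)C(C)ON1C(=O)c2ccccc2C1=O`: 51% in this assay
Compound 3 `CCCOC(=O)C(C)ON1C(=O)c2ccccc2C1=O`: 64% in this assay

Compound 3 stands level with compound 1 in this assay (no change at the digits printed from compound 1 to compound 3 (within the scatter)), the two together the highest of the three numbers, with compound 2 furthest away (a number 13 percentage points higher from compound 2 to compound 3 (beyond the scatter)). Compound 4 `CCCCCOC(=O)C(C)ON1C(=O)c2ccccc2C1=O` differs from compound 3 by ethyl in place of hydrogen on a saturated chain carbon, three bonds along the chain from an oxygen next to a carbonyl group. The step bearing most on this is the earlier lengthening from compound 1 to compound 3 (no change at the digits printed from compound 1 to compound 3 (within the scatter)), which changed nothing beyond the scatter; the branching step a number 13 percentage points lower from compound 1 to compound 2 (beyond the scatter) is a different kind of change. Compound 4 is therefore expected to show a number 2 percentage points lower from compound 3 to compound 4 (within the scatter), giving an estimate of 62% (range 45% to 78%).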

Compound 4, percent growth inhibition at one concentration: 64%
Compound 4: the middle estimate sits 2 percentage points below what was measured; the measured number falls inside the stated range.
By their numbers in this assay, from the lowest: compound 2; then compounds 1, 3 and 4 (each within the scatter of the next).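

In this assay the added ethyl gave no change at the digits printed from compound 3 to compound 4 (within the scatter) and the whole span from methyl to pentyl gave no change at the digits printed from compound 1 to compound 4 (within the scatter), so the straight chains on this oxygen stay level up to pentyl. Pentyl also holds the gap to the branched isopropyl ester, with a number 13 percentage points higher from compound 2 to compound 4 (beyond the scatter), leaving compound 2 as the only one shown that stands apart from the straight chains. No evidence given here bears on the reason for this. From the compounds shown here alone, whether a chain longer than pentyl, or a chain ending in an amine or a carboxylic acid, would stay at this level remains open.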